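This account rests on a few compounds, and the source may have more. Where it says the series, first, only, none or still open, it means among the compounds named here.

Measured compounds in an ADME assay on HepG2 2.2.15 cells (Homo sapiens) for cytotoxicity; a higher number here means that more compound is tolerated, a lower number that less compound is tolerated:
compound 1, `O=C(Nc1ncc(Cc2ccc(F)cc2)s1)c1ccccc1`: "not toxic" (no number reported)
compound 2, `O=C(Nc1ncc(Cc2ccc(F)cc2)s1)c1ccc(Br)cc1`: > 50000 nM
compound 3, `CCCCCC(=O)Nc1ncc(C(Oc2ccc3cc(Br)ccc3c2)c2ccc(Cl)cc2)s1`: > 50000 nM

For compound 3 the result in this assay is a limit of the assay, not a measured number, so compound 3 stands at the ceiling of what this assay resolves. Compound 2 stands at the same ceiling, its result also being a limit. Compound 1 carries no number at all. For the measured compounds named here, two of the three entries therefore sit at the same edge (the limit of > 50000 nM in this assay, at which 2 of the 3 values shown sit), and no step between measured compounds is available to give a sense of how the amide side affects tolerance.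

Compound 4, `Cc1noc(C)c1C(=O)Nc1ncc(C(Oc2ccc3cc(Br)ccc3c2)c2ccc(Cl)cc2)s1`, differs from compound 3 in a single place: 3,5-dimethyl-1,2-oxazol-4-yl in place of pentyl on a carbonyl carbon. The rest of the molecule, including the bromonaphthyl ether and the chlorophenyl group on the same carbon, is unchanged.

With nothing in the series resolved below the ceiling, the expectation for compound 4 is that it behaves like compound 3 and compound 2 and is tolerated up to the limit. The step expected in this assay is a number no higher from compound 3 to compound 4 (the limit leaves the size open), that is none beyond the scatter. Compound 4 is expected to give 50000 nM, within 20000 nM to 120000 nM, and most likely the assay will again report only a limit.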

Compound 4, half-maximal cytotoxic concentration: "not toxic" (no number reported)
No number was reported for compound 4; no gap can be computed for the estimate.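

In this assay compound 4 gives "not toxic" (no number reported). Compound 3 stands at a limit of the assay. For the compounds shown here, no step from compound 3 to compound 4 can be read. The compounds shown leave open whether pentyl and 3,5-dimethyl-1,2-oxazol-4-yl on a carbonyl carbon differ at all in tolerance, with no compound resolved to a number: the limit of > 50000 nM in this assay, at which 2 of the 4 values shown sit.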